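The source may hold more compounds than are shown below. What is called first, only, known or untested is meant among the compounds shown, and "the series" means these compounds.

Three amides that share one core make up the measured series. In a functional assay on the whole organism with Mus musculus as the target (on this read-out lower numbers stand for an effect already at smaller amounts and higher numbers for an effect only at larger amounts of compound), compound 1 (`CC(C)NC(=O)CCC(=O)c1cccc(C(F)(F)F)c1`) gives > 200 mg/kg as a limit of the assay and not a number. Compound 2 (`CCC(C)NC(=O)CCC(=O)c1cccc(C(F)(F)F)c1`) gives > 200 mg/kg and this too is a limit. Compound 3 (`CC(C)CNC(=O)CCC(=O)c1cccc(C(F)(F)F)c1`) gives > 200 mg/kg as a limit as well, so it has no number of its own and stands with the other two: the limit of > 200 mg/kg in this assay, at which 3 of the 3 values shown sit, is all that the series shows so far.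

The next member is compound 4 (`CN1CCN(C(=O)CCC(=O)c2cccc(C(F)(F)F)c2)CC1`), with 4-methylpiperazin-1-yl in place of isobutylamino on a carbonyl carbon. The measured steps bear on this change only loosely. They all alter the group on an amide-type nitrogen, and none brings in a ring: a step that the two limits leave unreadable from compound 1 to compound 2, a step that the two limits leave unreadable from compound 1 to compound 3 and a step that the two limits leave unreadable from compound 2 to compound 3. From the compounds shown here alone, none of them has a size to carry over, so the direction in this assay stays open, and a further limit is the likeliest result. The estimated change, held only loosely, is a number no higher from compound 3 to compound 4 (the limit leaves the size open) as the expected step. Compound 4 is expected near 200 mg/kg as a rough estimate, within a range from 80 mg/kg to 400 mg/kg and with a limit again quite possible.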

Compound 4, dose for half-maximal effect: > 50 mg/kg
Compound 4 gave a limit, no number (the forecaster's own chance of this, stated with the estimate: 65%); the middle value is on the limit's open side.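

In this assay compound 4 gives > 50 mg/kg, which is a limit and not a number. Compound 1, compound 2 and compound 3 also stand at limits, so none of the steps to compound 4 can be read. The compounds shown leave open whether 4-methylpiperazin-1-yl in place of the open-chain amino groups changes the result in this assay, and in which direction.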